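This account rests on a few compounds, and the source may have more. Where it says the series, first, only, none or still open, it means among the compounds named here.

Measured in a toxicity assay on MT4 cells (Homo sapiens) for cytotoxicity, read by MTT assay; on this read-out higher numbers stand for lower toxicity in this test and lower numbers for higher toxicity in this test:
- compound 1 `Cc1cc(-c2ccc(F)cc2)cc(C)c1Oc1cc(N)nc(Nc2ccc(C#N)cc2)n1`: 23100 nM
- compound 2 `Cc1cc(-c2cccc(F)c2)ccc1Oc1cc(N)nc(Nc2ccc(C#N)cc2)n1`: 11300 nM
- compound 3 `Cc1cc(-c2ccc(F)cc2)ccc1Oc1cc(N)nc(Nc2ccc(C#N)cc2)n1`: 20100 nM

Compound 3, at 20100 nM, cannot be separated from the other two compounds. For the measured compounds named here, two measured steps bear on the next change: a 1.1-fold lower number from compound 1 to compound 3 (0.06 log units; within the scatter), with hydrogen in place of methyl, and a 1.8-fold higher number from compound 2 to compound 3 (0.25 log units; within the scatter), with 4-fluorophenyl in place of 3-fluorophenyl. Both lie within the scatter.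

Compound 4 `Cc1cc(-c2ccc(C#N)c(F)c2)ccc1Oc1cc(N)nc(Nc2ccc(C#N)cc2)n1` carries 4-cyano-3-fluorophenyl in place of 4-fluorophenyl on an aromatic carbon. Going by the values given here, no measured step introduces a nitrile, so the range stays wide. The estimated step is a 1.1-fold lower number from compound 3 to compound 4 (0.05 log units; within the scatter), and none beyond the scatter is expected. For compound 4 the expected value in this assay is 18000 nM, with an estimated range of 7000 nM to 42000 nM.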

Compound 4, half-maximal cytotoxic concentration: 6600 nM
Estimate against measurement, compound 4: 2.7-fold (0.44 log units) above, and the stated range ends above it.
By their numbers in this assay, from the lowest: compounds 4, 2, 3 and 1 (each within the scatter of the next, the first and the last beyond it).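

In this assay, for the compounds shown here, this position responds to substitution: 4-cyano-3-fluorophenyl in place of 4-fluorophenyl gives the first step beyond the scatter (a 3.0-fold lower number from compound 3 to compound 4 (0.48 log units; beyond the scatter)). Cyano in place of hydrogen alone stays within the scatter (a 1.7-fold lower number from compound 2 to compound 4 (0.23 log units; within the scatter)), so the larger step cannot be assigned to the nitrile by itself. Nothing measured here accounts for the lower number.

Open, on these data alone, is what a 4-cyanophenyl group without fluorine would give. Also open, as far as these compounds go, is how an amine or a carboxylic acid at this position would read.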